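A few compounds are considered here, and "the series" means these few. Any claim that something is new, unique, unknown or untested is made for them only; others in the source may bear on it.

Working notes on the series. The shared core of compound 1 `Cc1cc(Nc2cc(-c3ccccc3)[nH]n2)n2nc(SCCc3ccccc3)nc2n1` carries a phenethylsulfanyl group, and in a functional assay on PC-9 cells (Homo sapiens) for inhibition, read by MTT assay, with a stated time of 72 h (on this read-out lower numbers stand for stronger inhibition and higher numbers for weaker inhibition), compound 1 gives 4930 nM. Among the three measured compounds, compound 1 stands second highest. Compound 2 `Cc1cc(Nc2cc(-c3ccccc3)[nH]n2)n2nc(SCc3ccc(F)cc3)nc2n1` gives 8110 nM in this assay, and compound 3 `Cc1cc(Nc2cc(-c3ccccc3)[nH]n2)n2nc(SCc3ccc(Br)cc3)nc2n1` gives 4760 nM. The steps between them are all small: a 1.6-fold higher number from compound 1 to compound 2 (0.22 log units; within the scatter), a 1.0-fold lower number from compound 1 to compound 3 (0.02 log units; within the scatter) and a 1.7-fold lower number from compound 2 to compound 3 (0.23 log units; within the scatter), so changing the aryl group on the saturated chain carbon bound to a sulfur, or the halogen on that aryl, leaves the read-out within the scatter.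

Compound 4 `Cc1cc(Nc2cc(-c3ccccc3)[nH]n2)n2ncnc2n1` differs from compound 1 by hydrogen in place of phenethylsulfanyl on an aromatic carbon. Going by the values given here, none of the measured steps removes the whole sulfur-linked group; they only vary what hangs on it, so they bear on this step only by showing the read-out is insensitive to that variation. Removal of the group itself has no precedent in the series. A loss in this assay is expected, with compound 4 estimated at 15000 nM (range 5000 nM to 50000 nM), a step of a 3.0-fold higher number from compound 1 to compound 4 (0.48 log units; beyond the scatter) from compound 1.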

Compound 4, half-maximal inhibitory concentration: > 50000 nM
Compound 4: a limit, no number (the forecaster's own chance of this, stated with the estimate: 25%); middle value at least 3.3-fold (0.52 log units) away from the limit.
By their numbers in this assay, from the lowest: compounds 3, 1 and 2 (each within the scatter of the next). At a limit, above all of these: compound 4.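

In this assay compound 4 stands only as a limit, not a number: the limit of > 50000 nM in this assay, at which 1 of the 4 values shown sits.

The earlier compounds shown here varied only what hangs on the sulfur and stayed within the scatter of one another, whereas hydrogen in place of the whole sulfur-linked group gives an at least 10-fold higher number from compound 1 to compound 4 (1.00 log units; beyond the scatter) and an at least 10-fold higher number from compound 3 to compound 4 (1.02 log units; beyond the scatter) and also an at least 6.1-fold higher number from compound 2 to compound 4 (0.78 log units; beyond the scatter) as steps beyond the scatter. This position, on an aromatic carbon between two ring nitrogen atoms, therefore gives similar read-outs with phenethylsulfanyl, (4-fluorobenzyl)sulfanyl and (4-bromobenzyl)sulfanyl, but the read-out moves beyond the scatter when hydrogen stands there.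

The compounds shown leave open which part of the group the read-out depends on, the sulfur or the aryl ring. A small methylsulfanyl group, or an amine linking the same benzyl group in place of the sulfur, would bear on that question.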